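Compound 2 and a furan-2-yl replacement

The compounds below may be only part of what the source reports. "The series", "measured", "known", "first", "only" and "open" are said of these compounds alone.

Measured so far in a functional assay on PC-3 cells (Homo sapiens) for antiproliferative activity, read by CCK-8 assay, with a stated time of 6 days; a lower number here means a stronger inhibitor, a higher number a weaker inhibitor
Compound 1 `N#Cc1ccc(N2CCc3cc(-c4cnc5ccccc5c4)ccc32)cc1C(F)(F)F`: "not determined" (no result reported)
Compound 2 `CCN(c1ccc(C#N)c(Cl)c1)c1cc(-c2ccco2)ccc1C`: > 30000 nM
Compound 3 `Cc1noc(C)c1-c1cccc2c1CCCN2c1ccc(C#N)c(C(F)(F)F)c1`: "not determined" (no result reported)

In this assay compound 2 gives > 30000 nM as its reading, and this is a limit of the assay and not a number. Within the data shown here, compound 1 and compound 3 have no reported result, so no measured step between these compounds is available for comparison.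

Compound 4 `CCN(c1ccc(C#N)c(Cl)c1)c1cc(-c2c[nH]nc2C)ccc1C` has yet to be measured. It carries 3-methyl-1H-pyrazol-4-yl in place of furan-2-yl on an aromatic carbon (that is 3-methyl-1H-pyrazol-4-yl in place of furan-2-yl on an aromatic carbon) para to a methyl group.

The expected change in this assay is an at least 1.2-fold lower number from compound 2 to compound 4 (0.07 log units; that floor lies within the scatter) and is estimated to stay within the scatter, toward a lower number if it moves at all. This expectation rests on compound 2 alone, whose limit of > 30000 nM leaves the true size of the step open. Compound 4 is estimated at 25000 nM with an expected range from 8000 nM to 50000 nM in this assay and may itself come out only as a limit.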

Compound 4, half-maximal inhibitory concentration: 9030 nM
The estimate for compound 4 lay 2.8-fold (0.44 log units) above the measured number; measured number inside the range.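

Compound 2 stands at > 30000 nM in this assay, which is a limit of the assay and not a number. Placing 3-methyl-1H-pyrazol-4-yl in place of furan-2-yl, on the aromatic carbon para to a methyl group, gives an at least 3.3-fold lower number from compound 2 to compound 4 (0.52 log units; beyond the scatter), which shows that the reading responds to the group at this position and that compound 4 yields a single number, 9030 nM. The step is therefore a bound, and its true size stays open: the limit of > 30000 nM in this assay, at which 1 of the 4 values shown sits.

The change alters the ring, its hetero atoms and the methyl group in one move, so the compounds shown do not tell which of these parts accounts for the step. Also open, on these data alone, is how the number would respond at this carbon to a plain 1H-pyrazol-4-yl, an amine or a carboxylic acid.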